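Aminothiadiazole for triazole on the thioether of compound 3

A few compounds are considered here, and "the series" means these few. Any claim that something is new, unique, unknown or untested is made for them only; others in the source may bear on it.

Compound 3 `O=[N+]([O-])c1ccc(-c2nc(CO[C@@H]3O[C@H](CSc4ncn[nH]4)[C@H]4OC5(CCCC5)O[C@@H]34)no2)cc1` carries a nitrophenyl-bearing oxadiazole on one side of the shared core and a (1H-1,2,4-triazol-5-yl)sulfanyl group on the other. Going by the values given here, in a functional assay on T47D cells (Homo sapiens) for antiproliferative activity, read by sulforhodamine B assay, with a stated time of 48 h (on this read-out lower numbers stand for stronger inhibition of growth and higher numbers for weaker inhibition of growth), compound 3 gives 20000 nM, the lower of the two numbers measured so far. Compound 2 `COc1cc(-c2nc(CO[C@@H]3O[C@H](CSc4nnc(N)s4)[C@H]4OC5(CCCC5)O[C@@H]34)no2)cc(OC)c1OC` joins the (5-amino-1,3,4-thiadiazol-2-yl)sulfanyl group to a trimethoxyphenyl-substituted oxadiazole and gives 42000 nM in this assay. Compound 1 `Cc1ccc(S(=O)(=O)OC[C@H]2O[C@@H](OCc3noc(-c4ccc([N+](=O)[O-])cc4)n3)[C@@H]3OC4(CCCC4)O[C@@H]32)cc1` keeps the ((4-methylphenyl)sulfonyl)oxy group in place of a thioether; in this assay compound 1 reaches only a limit, > 100000 nM, as noted in the limit of > 100000 nM in this assay, at which 1 of the 3 values shown sits. Among the compounds with values here, the single measured step, an at least 5.0-fold lower number from compound 1 to compound 3 (0.69 log units; beyond the scatter), shows that the thioether heterocycle matters for the read-out.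

Compound 4 `Nc1nnc(SC[C@H]2O[C@@H](OCc3noc(-c4ccc([N+](=O)[O-])cc4)n3)[C@@H]3OC4(CCCC4)O[C@@H]32)s1` follows from compound 3 by 5-amino-1,3,4-thiadiazol-2-yl in place of 1H-1,2,4-triazol-5-yl on a sulfur. Within the data shown here, no measured pair isolates this exchange on a common aryl. Among the measured compounds shown here, compound 2, which carries the entering group on a different aryl, gives 42000 nM in this assay, and that number sits higher than the one of compound 3. A step from compound 3 to compound 4 of a 1.5-fold higher number from compound 3 to compound 4 (0.18 log units; within the scatter) is therefore expected, toward a somewhat weaker number. Compound 4 is estimated at 30000 nM, within 10000 nM to 100000 nM.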

Compound 4, concentration for 50% growth inhibition: 19000 nM
For compound 4 the middle estimate is 1.6-fold (0.20 log units) above the measured one; the range from low to high includes it.
By their numbers in this assay, from the lowest: compounds 4 and 3 (each within the scatter of the next); then compound 2. At a limit, above all of these: compound 1.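

With the 4-nitrophenyl held fixed, the exchange on the sulfur can now be read directly: a 1.1-fold lower number from compound 3 to compound 4 (0.02 log units; within the scatter), so this assay does not separate the 5-amino-1,3,4-thiadiazol-2-yl from the 1H-1,2,4-triazol-5-yl here. Going by these compounds alone, with the (5-amino-1,3,4-thiadiazol-2-yl)sulfanyl held fixed, the aryl exchange can also be read for the first time: a 2.2-fold lower number from compound 2 to compound 4 (0.34 log units; beyond the scatter), a modest step beyond the scatter that places the higher number of this pair with the 3,4,5-trimethoxyphenyl. Replacing the ((4-methylphenyl)sulfonyl)oxy with a second sulfur-linked heterocycle gives a further step, an at least 5.2-fold lower number from compound 1 to compound 4 (0.72 log units; beyond the scatter), whose size is bounded by a limit: the limit of > 100000 nM in this assay, at which 1 of the 4 values shown sits.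

Going by these compounds, whether the aryl step also holds with the 1H-1,2,4-triazol-5-yl on the sulfur remains open. So does the outcome with a simple amine or a carboxylic acid in place of the sulfur-linked heterocycle on the saturated chain carbon.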